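From 2-aminophenyl to 4-methylphenyl on the shared core

The compounds below may be only part of what the source reports. "The series", "measured", "known", "first", "only" and "open" are said of these compounds alone.

Compound 3 `Nc1ccccc1Nc1nc(-c2cccc(F)c2)nc2ccc(F)cc12` carries a 2-aminophenyl group on a nitrogen on an aromatic ring. In a functional assay on COLO 205 cells (Homo sapiens) for cytotoxicity, read by MTT assay, with a stated time of 48 h (on this read-out higher numbers stand for weaker inhibition and lower numbers for stronger inhibition), compound 3 gives > 50000 nM, which is a limit of the assay and not a number. Compound 1 `Fc1ccc(Nc2nc(-c3cccc(F)c3)nc3ccc(F)cc23)cc1`, with 4-fluorophenyl in that place, gives > 50000 nM, also a limit. Compound 2 `Fc1cccc(-c2nc(Nc3ccc(Cl)cc3)c3cc(F)ccc3n2)c1`, with 4-chlorophenyl there, gives a real number, 32600 nM.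

Compound 4 `Cc1ccc(Nc2nc(-c3cccc(F)c3)nc3ccc(F)cc23)cc1` has 4-methylphenyl in place of 2-aminophenyl on a nitrogen on an aromatic ring. Going by the values given here, three measured steps bear on this change. They are an at least 1.5-fold higher number from compound 2 to compound 3 (0.18 log units; that floor lies within the scatter), an at least 1.5-fold lower number from compound 1 to compound 2 (0.18 log units; that floor lies within the scatter) and a step that the two limits leave unreadable from compound 1 to compound 3. None can be read as a step beyond the scatter because of the limit of > 50000 nM in this assay, at which 2 of the 3 values shown sit. In this assay, then, weak inhibition is expected to continue, with no clear step beyond the scatter. The expected change is an at least 1.1-fold lower number from compound 3 to compound 4 (0.07 log units; that floor lies within the scatter), and the assay may again report only a limit. Compound 4 is estimated at 42000 nM, with an expected range from 18000 nM to 70000 nM.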

Compound 4, half-maximal inhibitory concentration: > 50000 nM
Compound 4 ended at the assay's limit; the forecaster's own chance of this, stated with the estimate: 55%; at least 1.1-fold (0.07 log units) between middle value and limit.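

The steps from compound 3 and from compound 1 to compound 4 cannot be read, because both ends of each are limits and not numbers in this assay, a situation now shared by most of the series: the limit of > 50000 nM in this assay, at which 3 of the 4 values shown sit.

Compound 4 adds a third group at this place that ends at the limit: 4-methylphenyl, with 0 hydrogen-bond donors, joins 2-aminophenyl, with 1 hydrogen-bond donor. Going by these compounds alone, the one step that can be read, methyl in place of chloro on an aromatic carbon, is an at least 1.5-fold higher number from compound 2 to compound 4 (0.18 log units; that floor lies within the scatter), so compound 2, the only compound with a real number, is not set apart from compound 4 beyond the scatter.

From the compounds shown here alone, what a carboxylic acid or a longer chain in place of the methyl would give stays open. So does whether any group on this nitrogen can bring a value clearly lower than that of compound 2.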